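Acetyl in Place of Methylsulfanyl: Expected Binding

The source may hold more compounds than are shown below. What is called first, only, known or untested is meant among the compounds shown, and "the series" means these compounds.

Measured so far:
compound 1, `CCCCN(CC)c1nc(C)nc2c1nnn2-c1c(C)cc(C)nc1C`, 65 nM
compound 2, `CCCCN(CC)c1nc(C)nc2c1nnn2-c1ccc(Br)cc1Br`, 20.4 nM
compound 3, `CCCCN(CC)c1nc(C)nc2c1nnn2-c1ccc(SC)cc1Br`, 10.6 nM

These three share one core and differ only in the aromatic group attached to it. In an in vitro assay on 293-EBNA cells for binding affinity to corticotropin-releasing factor receptor 1 (Homo sapiens) (a higher number here means a weaker inhibitor, a lower number a stronger inhibitor), compound 3 gives the lowest number of the three, yet its gap to compound 2 lies within the scatter, while compound 1 stands beyond it. Among the measured compounds shown here, the only single-point change measured is a 1.9-fold lower number from compound 2 to compound 3 (0.28 log units; within the scatter), a step too small to count. Compound 4, `CCCCN(CC)c1nc(C)nc2c1nnn2-c1ccc(C(C)=O)cc1Br`, carries the change (acetyl in place of methylsulfanyl on an aromatic carbon). For the measured compounds named here, a group without a ring replaces another group without a ring, and the one comparable swap at that place moved nothing, so no step beyond the scatter is expected: a 1.4-fold higher number from compound 3 to compound 4 (0.15 log units; within the scatter). Compound 4 is therefore estimated at 15 nM, with a likely range from 6 nM to 40 nM.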

Compound 4, inhibition constant: 33.7 nM
For compound 4 the middle estimate is 2.2-fold (0.35 log units) below the measured one, within the range that was stated.
By their numbers in this assay, from the lowest: compounds 3, 2, 4 and 1 (each within the scatter of the next, the first and the last beyond it).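

This position is sensitive to the group it carries: with the counts of hydrogen-bond donors and acceptors unchanged, acetyl in place of methylsulfanyl gives in this assay a 3.2-fold higher number from compound 3 to compound 4 (0.50 log units; beyond the scatter), a step beyond the scatter, unlike the earlier swap at this place. Acetyl and bromo, by contrast, remain indistinguishable, with a 1.7-fold higher number from compound 2 to compound 4 (0.22 log units; within the scatter) as their step. Nothing available here explains the difference between these swaps. Still open, from the compounds shown here alone, is how an amine, a carboxylic acid or a longer chain would behave at this position.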